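This account rests on a few compounds, and the source may have more. Where it says the series, first, only, none or still open, it means among the compounds named here.

Cytotoxicity notes on the series. In an ADME assay on MT4 cells (Homo sapiens) for cytotoxicity, read by MTT assay, with a stated time of 5 days (a lower number here means that less compound is tolerated, a higher number that more compound is tolerated), compound 3 `COc1cc2nc([S+]([O-])CC(=O)Nc3ccc([N+](=O)[O-])cc3)nc(Nc3c(Cl)cc(/C=C/C#N)cc3Cl)c2cc1OC` gives 92800 nM; compound 1 `COc1cc2nc(SCC(=O)Nc3ccc(S(N)(=O)=O)cc3)nc(Nc3c(Cl)cc(/C=C/C#N)cc3Cl)c2cc1OC` gives 116000 nM, which is not separated from compound 3 beyond the scatter, while compound 2 `COc1cc2nc([S+]([O-])CC(=O)Nc3ccc([N+](=O)[O-])cc3)nc(Nc3c(C)cc(/C=C/C#N)cc3C)c2cc1OC` gives 189000 nM, and the step of a 2.0-fold lower number from compound 2 to compound 3 (0.31 log units; beyond the scatter) is the only one beyond the scatter among the three. Compound 4 `COc1cc2nc([S+]([O-])CC(=O)Nc3cc([N+](=O)[O-])ccc3F)nc(Nc3c(Cl)cc(/C=C/C#N)cc3Cl)c2cc1OC` differs from compound 3 by 2-fluoro-5-nitrophenyl in place of 4-nitrophenyl on an amide-type nitrogen. No measured step touches the aryl group on the amide-type nitrogen: the one step shown, a 2.0-fold lower number from compound 2 to compound 3 (0.31 log units; beyond the scatter), concerns the other anilino group and was modest. No basis therefore exists for expecting movement beyond the scatter in this assay, and the expected step is a 1.0-fold lower number from compound 3 to compound 4 (0.01 log units; within the scatter). For compound 4 the estimate in this assay is 90000 nM, with a range from 45000 nM to 180000 nM.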

Compound 4, half-maximal cytotoxic concentration: > 194000 nM
Compound 4: only a limit was reported; the forecaster's own chance of this, stated with the estimate: 10%; at least 2.1-fold (0.33 log units) between middle value and limit.
By their numbers in this assay, from the lowest: compounds 3, 1 and 2 (each within the scatter of the next, the first and the last beyond it). At a limit, above all of these: compound 4.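

In this assay the aryl group on the amide-type nitrogen proves able to move the number: 2-fluoro-5-nitrophenyl in place of 4-nitrophenyl gives an at least 2.0-fold higher number from compound 3 to compound 4 (0.32 log units; beyond the scatter) and is the first step shown at this position. Compound 4 is reported only as a limit, so this step has a floor and no measured size: the limit of > 194000 nM in this assay, at which 1 of the 4 values shown sits.

The change brings in the fluorine and shifts the nitro group together, and the compounds shown do not tell these two apart. From the compounds shown here alone, how an amine or a carboxylic acid in place of the nitro group would read in this assay also stays open.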